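This account rests on a few compounds, and the source may have more. Where it says the series, first, only, none or still open, it means among the compounds named here.

In an assay on isolated protein for inhibition of Rho-associated protein kinase 2 (Homo sapiens), read by scintillation counting, radiometric assay and 33P incorporation, with a stated time of 40 min, in the presence of a further agent that is not named here (a higher number here means a weaker inhibitor, a lower number a stronger inhibitor), compound 3 `CCCc1ccc(C(=O)Nc2cccc(NC(=O)COc3ccc4c(=O)ccoc4c3)c2)cc1` gives 14 nM, the lowest of the two numbers measured, while compound 1 `CN(C)c1ccc(C(=O)Nc2cccc(NC(=O)COc3ccc4c(c3)NC(=O)CC4)c2)cc1` gives 3140 nM. Compound 2 `COc1ccc(OCC(=O)Nc2cccc(NC(=O)c3ccc(N(C)C)cc3)c2)cc1OC` reaches only a limit, > 10000 nM, as the limit of > 10000 nM in this assay, at which 1 of the 3 values shown sits, records. Among the compounds with values here, the single measured step, an at least 3.1-fold higher number from compound 1 to compound 2 (0.50 log units; beyond the scatter), changes the group on an oxygen on a saturated carbon and therefore does not bear on the change that leads to compound 4 `CC(C)(C)c1cc(C(=O)Nc2cccc(NC(=O)COc3ccc4c(=O)ccoc4c3)c2)no1`: 5-(tert-butyl)-1,2-oxazol-3-yl in place of 4-propylphenyl on a carbonyl carbon. Within the data shown here, no measured step touches the group on this carbonyl carbon, so neither direction nor size can be read from the data. For compound 4 a step of moderate size in either direction is expected, a 3.6-fold higher number from compound 3 to compound 4 (0.55 log units; beyond the scatter). Compound 4 is accordingly estimated at 50 nM, within a range of 10 nM to 300 nM.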

Compound 4, half-maximal inhibitory concentration: 5 nM
Estimate against measurement, compound 4: 10-fold (1.00 log units) above, and the stated range ends above it.
By their numbers in this assay, from the lowest: compound 4; then compound 3; then compound 1. At a limit, above all of these: compound 2.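

In this assay, putting 5-(tert-butyl)-1,2-oxazol-3-yl in place of 4-propylphenyl on a carbonyl carbon gives a 2.8-fold lower number from compound 3 to compound 4 (0.45 log units; beyond the scatter). This first measured change at this place shows that the six-membered aromatic ring of carbon only is not needed there: a five-membered aromatic ring, with the same count of heavy atoms, is accepted and the number falls. Nothing measured here accounts for this fall. The compounds shown do not separate the ring from the tert-butyl group: how a 4-(tert-butyl)phenyl or a 5-methyl-1,2-oxazol-3-yl group on this carbonyl carbon would read stays open.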